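The source may hold more compounds than are shown below. What is called first, only, known or untested is meant among the compounds shown, and "the series" means these compounds.

Working notes on the series. In a functional assay on K562 cells (Homo sapiens), read by MTT assay, with a stated time of 72 h (on this read-out lower numbers stand for stronger inhibition and higher numbers for weaker inhibition), compound 1 (`Cc1nc(N)c2c(-c3ccco3)cn([C@@H]3O[C@H](CO)[C@@H](O)[C@H]3O)c2n1`) gives > 20000 nM as a limit of the assay. Compound 2 (`Cc1nc(N)c2c(-c3ccoc3)cn([C@@H]3O[C@H](CO)[C@@H](O)[C@H]3O)c2n1`) gives > 20000 nM as a limit too. Compound 3 (`Cc1nc(N)c2c(-c3ccccc3)cn([C@@H]3O[C@H](CO)[C@@H](O)[C@H]3O)c2n1`) gives > 20000 nM as a limit as well, so it has no number and stands with the other two at the limit of > 20000 nM in this assay, at which 3 of the 3 values shown sit, in the series.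

The next entry is compound 4 (`Cc1nc(N)c2c(I)cn([C@@H]3O[C@H](CO)[C@@H](O)[C@H]3O)c2n1`), with iodo in place of phenyl on an aromatic carbon is the whole change.

The measured steps give no size to carry over: a step that the two limits leave unreadable from compound 1 to compound 2 and a step that the two limits leave unreadable from compound 1 to compound 3 and a step that the two limits leave unreadable from compound 2 to compound 3 all stay unreadable. Each swaps one aromatic ring for another, and none shows a ring leaving that carbon. Any expectation is therefore weak, leaning towards stronger inhibition or no readable change in this assay only.

The expected step is an at least 1.4-fold lower number from compound 3 to compound 4 (0.15 log units; that floor lies within the scatter) and remains an estimate. For compound 4 the estimated value is 14000 nM with an expected range from 1500 nM to 20000 nM in this assay.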

Compound 4, half-maximal inhibitory concentration: 5120 nM
The estimate for compound 4 lay 2.7-fold (0.44 log units) above the measured number; low and high end bracket the measured number.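

In this assay, iodo on the aromatic carbon two ring bonds from the ring nitrogen gives the series its first number, while the compounds with an aromatic ring there remain at a limit of the assay: the limit of > 20000 nM in this assay, at which 3 of the 4 values shown sit.

Replacing the ring with iodo gives an at least 3.9-fold lower number from compound 3 to compound 4 (0.59 log units; beyond the scatter), and the two furans give an at least 3.9-fold lower number from compound 2 to compound 4 (0.59 log units; beyond the scatter) and an at least 3.9-fold lower number from compound 1 to compound 4 (0.59 log units; beyond the scatter). This shows that the substituent at this position can change the read-out, which the ring-for-ring steps could not show, as none of them can be read.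

With iodo as the only non-ring group, the compounds shown cannot separate an effect of iodine itself from that of losing the ring. As far as these compounds go, whether bromo, chloro, methyl or an amine on this carbon would give a similar number remains open.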